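The source may report more compounds than this note shows. Statements on the series, on what has been measured and on what is new or still open speak of the compounds shown alone.

Measured in a functional assay on B16 cells (Mus musculus) for inhibition; a higher number here means a weaker inhibitor, a lower number a stronger inhibitor:

Compound 1 `NC(=S)Nc1ccc(O)cc1`: 6300 nM
Compound 2 `CCc1ccccc1NC(N)=S`: > 10000 nM (a limit)

Compound 2 has no exact number, and its > 10000 nM is only a limit of this assay. Compound 3 `CC(C)(C)c1ccccc1NC(N)=S`, not yet measured, carries tert-butyl in place of ethyl on an aromatic carbon. Among the compounds with values here, no measured pair of compounds shows a step of this kind, so the expectation rests on little. The estimated step of a number no higher from compound 2 to compound 3 (the limit leaves the size open) in this assay is no larger than the usual scatter, with no direction expected. Compound 3 is expected at about 10000 nM, with an estimated range from 3000 nM to 30000 nM.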

Compound 3, half-maximal inhibitory concentration: > 10000 nM
Compound 3 was reported as a limit (the forecaster's own chance of this, stated with the estimate: 55%); the middle value lies on the limit itself.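

No step can be read from compound 2 to compound 3, because both are reported only as limits: the limit of > 10000 nM in this assay, at which 2 of the 3 values shown sit.

From the compounds shown here alone, how compound 2 and compound 3 truly compare in this assay, and so what tert-butyl in place of ethyl does, remains open.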